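This account rests on a few compounds, and the source may have more. Where it says the series, first, only, none or still open, it means among the compounds named here.

In a functional assay on Caco-2 cells (Homo sapiens) for inhibition, read by sulforhodamine B assay, with a stated time of 48 h (a lower number here means a stronger inhibitor, a higher number a weaker inhibitor), the measured compounds read as follows:

Compound 1 `COC(=O)[C@H]1C[C@@H](c2coc3ccccc3c2=O)N(c2ccccc2)O1` gives > 60000 nM (a limit).
Compound 2 `CCO[C@H]1C[C@@H](c2coc3ccccc3c2=O)N(c2ccccc2)O1` gives > 60000 nM (a limit).
Compound 3 `O=c1c([C@@H]2C[C@H](c3ccccc3)ON2c2ccccc2)coc2ccccc12` gives > 60000 nM (a limit).

Compound 2 is known only through the limit > 60000 nM and not as a number. Compound 4 `CCO[C@H]1C[C@@H](c2coc3ccc(C)cc3c2=O)N(c2ccccc2)O1` differs from it by methyl in place of hydrogen on an aromatic carbon. The measured steps nearest this change are a step that the two limits leave unreadable from compound 1 to compound 2 and a step that the two limits leave unreadable from compound 2 to compound 3 (both on a saturated ring carbon), so neither gives a size. All the evidence sits at one value (the limit of > 60000 nM in this assay, at which 3 of the 3 values shown sit). No step beyond the scatter is therefore expected in this assay and no direction can be given, the expected step being a number no higher from compound 2 to compound 4 (the limit leaves the size open) (an estimate). Compound 4 is estimated at 60000 nM (expected range 30000 nM to 120000 nM).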

Compound 4, half-maximal inhibitory concentration: 31000 nM
Compound 4: middle estimate off by 1.9-fold (0.29 log units), on the high side; the range from low to high includes it.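

In this assay, going by these compounds alone, compound 4 gives 31000 nM, the only number among the values shown, so methyl in place of hydrogen on this aromatic carbon leaves a readable value with the ethoxy group retained. The change gives an at least 1.9-fold lower number from compound 2 to compound 4 (0.28 log units; that floor lies within the scatter), so the floor of the step does not establish a change beyond the scatter. Its true size stays open because compound 2 is known only by its limit: the limit of > 60000 nM in this assay, at which 3 of the 4 values shown sit.

What the compounds shown leave open is whether a larger group here, such as ethyl, methoxy or an amine, would move the number further. Also open, from the compounds shown here alone, is whether methyl would act alike with phenyl or methoxycarbonyl in place of the ethoxy group.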